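Chloro to Methyl on a Shared Core and Cell Toxicity

The source may hold more compounds than are shown below. What is called first, only, known or untested is meant among the compounds shown, and "the series" means these compounds.

Measured compounds:
Compound 1 `O=c1[nH]c2ccc(Cl)cc2n1Cc1c(F)cccc1F`: in an ADME assay on MT4 cells (Homo sapiens) for cytotoxicity (on this read-out lower numbers stand for higher toxicity in this test and higher numbers for lower toxicity in this test), compound 1 gives > 424000 nM, which is a limit of the test rather than a number.
Compound 2 `Cc1cc(C)cc(Cn2c(=O)[nH]c3ccc(Cl)cc32)c1`: in this assay compound 2 gives 8900 nM.
Compound 3 `Cc1ccc2[nH]c(=O)n(Cc3c(F)cccc3F)c2c1`: in this assay compound 3 gives 236000 nM.

Compound 3 differs from compound 1 by one change (methyl in place of chloro on an aromatic carbon), and the step is an at least 1.7-fold lower number from compound 1 to compound 3 (0.25 log units; that floor lies within the scatter); its size is only a floor because of the limit of > 424000 nM in this assay, at which 1 of the 3 values shown sits. Compound 2 differs from compound 1 in more than one place, and the difference between the two cores is not broken down here. Compound 4 `Cc1cc(C)cc(Cn2c(=O)[nH]c3ccc(C)cc32)c1` is not yet measured; it differs from compound 2 by the same change (methyl in place of chloro on an aromatic carbon), at the same place. From compound 2 to compound 4 the expected step is a 1.5-fold lower number from compound 2 to compound 4 (0.17 log units; within the scatter), resting on an at least 1.7-fold lower number from compound 1 to compound 3 (0.25 log units; that floor lies within the scatter) from compound 1 to compound 3, whose floor lies within the scatter. For compound 4 the estimate is 6000 nM, expected between 2000 nM and 20000 nM.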

Compound 4, half-maximal cytotoxic concentration: 856 nM
Compound 4: the middle estimate sits 7.0-fold (0.85 log units) above what was measured; measured number below the stated range.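

Carried to a second core, methyl in place of chloro brings a 10-fold lower number from compound 2 to compound 4 (1.02 log units; beyond the scatter) in this assay, so on this core the change clearly goes with higher toxicity in the test. This does not show that the change acts differently on the two cores, nor that it acts alike: the same change on two cores in this assay, an at least 1.7-fold lower number (0.25 log units; that floor lies within the scatter) from compound 1 to compound 3 and a 10-fold lower number (1.02 log units; beyond the scatter) from compound 2 to compound 4; the limit leaves it open whether they differ. The earlier step can be read only as a floor because compound 1 stands at a limit of the test, not at a number: the limit of > 424000 nM in this assay, at which 1 of the 4 values shown sits.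

The compounds shown leave open how a fluoro, a methoxy or an amine on the same aromatic carbon would compare with chloro and methyl. They also leave open how large the step would be on a third core.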